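The source may report more compounds than this note shows. Statements on the series, on what has been measured and on what is new or still open speak of the compounds shown alone.

Among the three compounds tested so far in a functional assay on MDA-MB-468 cells (Homo sapiens) for antiproliferative activity, read by MTT assay (a lower number here means a stronger inhibitor, a higher number a weaker inhibitor), compound 3 `COc1ccc(/C=C/c2cc(OC)c(OC)c(OC)c2)c(O)c1` gives 5300 nM. That lies within the usual scatter of compound 1 `COc1ccc(/C=C/c2cc(Br)ccc2O)c(OC)c1`, which gives 3700 nM, while compound 2 `COc1cccc(/C=C\c2cc(OC)c(OC)c(OC)c2)c1O` gives 2600 nM, a lower number that falls just beyond the scatter from compound 3. Compound 4 `COc1cc(/C=C/c2ccc(OC)cc2O)cc(OC)c1` has hydrogen in place of methoxy on an aromatic carbon of compound 3, at the place ortho to two methoxy groups and para to a large group (hydrogen in place of methoxy on an aromatic carbon). For the measured compounds named here, no measured pair shows this change alone, so the data offer no direct guide. The expected step is a 1.1-fold higher number from compound 3 to compound 4 (0.05 log units; within the scatter), a slight rise in the number that stays within the scatter. For compound 4 the estimated value is 6000 nM, with an expected range from 2000 nM to 18000 nM.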

Compound 4, half-maximal inhibitory concentration: 8400 nM
The estimate for compound 4 lay 1.4-fold (0.15 log units) below the measured number, within the range that was stated.
By their numbers in this assay, from the lowest: compounds 2, 1, 3 and 4 (each within the scatter of the next, the first and the last beyond it).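

Hydrogen in place of the methoxy group that sits ortho to two methoxy groups and para to a large group gives a 1.6-fold higher number from compound 3 to compound 4 (0.20 log units; within the scatter) in this assay and so offers the first direct reading at this position. The methoxy group there is not needed to keep compound 4 within the scatter of compound 3. No measurement here explains this result. Only methoxy and hydrogen have been compared at this position. Going by these compounds, how a fluorine atom, an amine or a longer chain such as ethoxy would fare there remains open.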